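Replacing the aryl group of a weak growth inhibitor

The source may report more compounds than this note shows. Statements on the series, on what has been measured and on what is new or still open speak of the compounds shown alone.

In a functional assay on DU-145 cells (Homo sapiens) for inhibition, read by trypan blue exclusion, with a stated time of 96 h (a higher number here means a weaker inhibitor of growth, a lower number a stronger inhibitor of growth), compound 1 `COc1ccccc1/C=C(\C(=O)c1ccc(Cl)cc1)S(=O)(=O)Cc1ccc(Cl)cc1` gives 25000 nM, compound 2 `CCOc1ccc(/C=C(\C(=O)c2ccc(Cl)cc2)S(=O)(=O)Cc2ccc(C)cc2)cc1OC` gives 10000 nM, and compound 3 `Cc1ccc(CS(=O)(=O)/C(=C/c2ccc(N(C)C)cc2)C(=O)c2ccc(Cl)cc2)cc1` gives 50000 nM. Compound 3 therefore carries the highest of the three numbers, although it lies within the scatter of compound 1 and is clearly separated only from compound 2.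

Compound 4 `COc1ccccc1/C=C(\C(=O)c1ccc(Cl)cc1)S(=O)(=O)Cc1ccc(C)cc1` departs from compound 3 in one place: 2-methoxyphenyl in place of 4-(dimethylamino)phenyl on a double-bonded chain carbon bound to a double-bonded chain carbon. Among the compounds with values here, the one measured step at this place is a 5.0-fold higher number from compound 2 to compound 3 (0.70 log units; beyond the scatter). It shows that replacing the group here can move the number beyond the scatter, but it involves a different partner for 4-(dimethylamino)phenyl, so it sets no size for this change. Compound 4 bears the same 2-methoxyphenyl as compound 1. The nearest guide is therefore compound 1, which gives 25000 nM. Within the data shown here, compound 1 also differs from compound 4 elsewhere, and no measured step covers that difference. The expectation is therefore a small move towards a lower number, not one clearly beyond the scatter. The estimated change is a 2.0-fold lower number from compound 3 to compound 4 (0.30 log units; within the scatter). For compound 4 the expected value is 25000 nM, with an estimated range from 10000 nM to 60000 nM.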

Compound 4, concentration for 50% growth inhibition: 10000 nM
Estimate against measurement, compound 4: 2.5-fold (0.40 log units) above; measured number inside the range.
By their numbers in this assay, from the lowest: compounds 2 and 4 (each within the scatter of the next); then compounds 1 and 3 (each within the scatter of the next).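

In this assay the change from 4-(dimethylamino)phenyl to 2-methoxyphenyl on a double-bonded chain carbon gives a 5.0-fold lower number from compound 3 to compound 4 (0.70 log units; beyond the scatter) and the comparison of 4-ethoxy-3-methoxyphenyl with 2-methoxyphenyl gives no change at the digits printed from compound 2 to compound 4 (within the scatter) so 4-(dimethylamino)phenyl now stands apart from two different groups at this place, while those two groups are not separated from each other. Within the data shown here, the change of chloro to methyl on an aromatic carbon, with 2-methoxyphenyl held in place, gives a 2.5-fold lower number from compound 1 to compound 4 (0.40 log units; beyond the scatter) and thus shows for the first time that a change away from this place can also move the number beyond the scatter. Nothing available here accounts for any of these steps.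

The compounds shown leave open whether the methyl-for-chloro step keeps its size with 4-ethoxy-3-methoxyphenyl or 4-(dimethylamino)phenyl at this place, and whether the separation of 4-(dimethylamino)phenyl from the other two groups persists with chloro in place of methyl. They also leave open whether a phenyl group carrying a carboxylic acid or a morpholine at this place would give a number closer to that of compound 3 or to that of compound 4.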